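The source may report more compounds than this note shows. Statements on the series, on what has been measured and on what is new or still open speak of the compounds shown alone.

Compound 1 `CCN1C(=O)/C(=C/c2ccnc3ccccc23)SC1=S`: 190000 nM
Compound 2 `CC(=O)/N=C1\NC(=O)/C(=C/c2ccc(-c3ccc([N+](=O)[O-])cc3)o2)S1`: 78000 nM
Compound 3 `CCOC(=O)C1=C(Nc2ccc([N+](=O)[O-])cc2)S/C(=C\c2ccc(N(C)C)cc2)C1=O`: 141000 nM

All three compounds were tested in an assay for inhibition of LL-diaminopimelate aminotransferase, chloroplastic (Arabidopsis thaliana); on this read-out higher numbers stand for weaker inhibition and lower numbers for stronger inhibition. In this assay compound 1 gives 190000 nM, compound 2 gives 78000 nM and compound 3 gives 141000 nM. The gaps between these three numbers all lie within the usual scatter of repeated measurements, so compound 3 does not stand apart from compound 1 or from compound 2, and all three are weak inhibitors on this read-out. Within the data shown here, the three compounds are built differently from one another, and no pair of them differs in only a single place, so no measured step is available to guide the next change.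

Compound 4 `CCOC(=O)C1=C(Nc2ccc(OC)cc2)S/C(=C\c2ccc(N(C)C)cc2)C1=O` has not yet been measured. It differs from compound 3 in one place: methoxy in place of nitro on an aromatic carbon. Among the measured compounds shown here, with no step of this kind among the measured compounds, the expectation rests on the numbers seen so far. Because compound 3 gives 141000 nM and the other two compounds sit in the same weak region, no large shift is expected. The expected step is small, a 1.1-fold higher number from compound 3 to compound 4 (0.03 log units; within the scatter), with no clear direction beyond the scatter. Compound 4 is therefore estimated at 150000 nM, in a range from 50000 nM to 450000 nM.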

Compound 4, half-maximal inhibitory concentration: > 200000 nM
Compound 4 gave a limit, no number; the forecaster's own chance of this, stated with the estimate: 30%; at least 1.3-fold (0.12 log units) between middle value and limit.
By their numbers in this assay, from the lowest: compounds 2, 3 and 1 (each within the scatter of the next, the first and the last beyond it). At a limit, above all of these: compound 4.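

Among these compounds, this is the first pair in the set that differs in only one place, so it gives the first direct look at the aromatic ring carrying the (4-nitrophenyl)amino group: putting methoxy in place of nitro on that ring gives an at least 1.4-fold higher number from compound 3 to compound 4 (0.15 log units; that floor lies within the scatter). In this assay compound 4 gives > 200000 nM, which is a limit of the assay and not a number. Among the compounds shown here, the change therefore brings no sign of stronger inhibition, though the size of the step cannot be read beyond its floor, and only one compound shown sits at this limit: the limit of > 200000 nM in this assay, at which 1 of the 4 values shown sits.

Going by these compounds, only nitro and methoxy appear at this position, so it remains open whether a different group there, such as an amine, a carboxylic acid or a chlorine atom, would give stronger inhibition or whether the ring would do as well with only hydrogen in that place. On these data alone, it also remains open whether the same change would have a similar outcome on the other parts of the shared core, which stay the same in this pair.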